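The source may hold more compounds than are shown below. What is called first, only, known or untested is meant among the compounds shown, and "the series" means these compounds.

Compound 1, `O=C(/C=C\Nc1ccc(Cl)cc1)c1cn(-c2ccccc2)nc1-c1ccccc1`, gives 11400 nM in a functional assay on U-87MG ATCC cells (Homo sapiens) for antiproliferative activity, read by MTT assay, with a stated time of 48 h; a higher number here means a weaker inhibitor, a lower number a stronger inhibitor. Compound 2, `O=C(/C=C\Nc1ccc(C(F)(F)F)cc1)c1cn(-c2ccccc2)nc1-c1ccccc1`, reaches only the assay limit of > 50000 nM. Compound 3, `O=C(/C=C\Nc1ccc(Cl)cc1)c1cn(-c2ccccc2)nc1-c1ccc(F)cc1`, gives 8900 nM.

Compound 3 holds the lower of the two numbers, yet the step of a 1.3-fold lower number from compound 1 to compound 3 (0.11 log units; within the scatter) lies within the scatter, so compound 3 and compound 1 stand level on the evidence shown. Compound 4, `COc1ccc(N/C=C\C(=O)c2cn(-c3ccccc3)nc2-c2ccc(F)cc2)cc1`, differs from compound 3 in one place: methoxy in place of chloro on an aromatic carbon. For the measured compounds named here, one measured step touches the same carbon. The step of an at least 4.3-fold higher number from compound 1 to compound 2 (0.64 log units; beyond the scatter) is at least modest, a loss whose full size stays hidden because the limit of > 50000 nM in this assay, at which 1 of the 3 values shown sits, caps the number for compound 2. Going by the values given here, that step replaced chloro with trifluoromethyl, not methoxy, so it gives a direction rather than a size: the one exchange made at that carbon so far moved the number upward. With no second point to fix the size, compound 4 is expected to sit somewhat higher than compound 3, with the step of a 1.7-fold higher number from compound 3 to compound 4 (0.23 log units; within the scatter) judged smaller than the trifluoromethyl case. The estimate for compound 4 is 15000 nM, with a range from 6000 nM to 40000 nM.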

Compound 4, half-maximal inhibitory concentration: 2500 nM
The estimate for compound 4 lay 6.0-fold (0.78 log units) above the measured number; the whole stated range lies above it.
By their numbers in this assay, from the lowest: compound 4; then compounds 3 and 1 (each within the scatter of the next). At a limit, above all of these: compound 2.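

Methoxy in place of chloro gives a 3.6-fold lower number from compound 3 to compound 4 (0.55 log units; beyond the scatter) in this assay, which shows that an exchange on this aromatic carbon, para to a large group, can also lower the number. The earlier exchange at this carbon, an at least 4.3-fold higher number from compound 1 to compound 2 (0.64 log units; beyond the scatter), ran the other way, so the number at this position can move in either direction depending on the group that enters, although the two exchanges start from compounds that differ by the fluoro group. Compound 2 stands at a limit, so the upward step has no full size and the spread between the two exchanges stays undefined: the limit of > 50000 nM in this assay, at which 1 of the 4 values shown sits.

With only chloro, trifluoromethyl and methoxy shown at this carbon, three groups give no basis for a rule about which kind of group lowers the number. As far as these compounds go, it remains open whether methoxy gives a similar step on compound 1, which lacks the fluoro group, and how a hydroxyl, an amine or a longer ether chain such as ethoxy would read at this position.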